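This account rests on a few compounds, and the source may have more. Where it says the series, first, only, none or still open, it means among the compounds named here.

Working notes on the diaryl-substituted series.

Compound 1 `Nc1nc(N)nc(-c2cccc(F)c2)n1` gives 70% in a functional assay on the whole organism with Rattus norvegicus as the target, at a dose of 20 mg/kg by the intraperitoneal route; a higher number here means more inhibition at the dose given (going by the name of the read-out), a lower number less inhibition. Compound 2 `Nc1nc(N)nc(-c2cccc(Br)c2)n1` gives 96% in this assay. Compound 3 `Nc1nc(N)nc(-c2cc(F)ccc2Br)n1` gives 78% in this assay. Compound 4 `Nc1nc(N)nc(-c2cc(Br)ccc2Br)n1` is not yet measured in this assay.

Two measured steps start from compound 1. The change bromo in place of fluoro on an aromatic carbon gave a number 26 percentage points higher from compound 1 to compound 2 (beyond the scatter). The change bromo in place of hydrogen on an aromatic carbon gave a number 8 percentage points higher from compound 1 to compound 3 (within the scatter), so compound 1 and compound 3 cannot be ordered on this read-out. Compound 2 stands above both of them beyond the scatter.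

The pending change is bromo in place of fluoro on an aromatic carbon. Within the data shown here, it is the same kind of change as the one from compound 1 to compound 2, not the same: in compound 3 the aromatic carbon that carries it is meta to a group of 8 heavy atoms and para to a bromo group (1 heavy atom), whereas in compound 1 it is meta to a group of 8 heavy atoms only. The two cores differ by bromo in place of hydrogen on an aromatic carbon, whose measured effect was a number 8 percentage points higher from compound 1 to compound 3 (within the scatter).

The step from compound 3 to compound 4 is expected to be a number 12 percentage points higher from compound 3 to compound 4 (beyond the scatter), smaller than a number 26 percentage points higher from compound 1 to compound 2 (beyond the scatter), because compound 3 already stands at 78%, a number that leaves less room for the read-out to go higher. Among the measured compounds shown here, this rests on one prior step only, the one from compound 1 to compound 2, so the expectation is loose. Compound 4 is estimated at 90%, with a likely range from 74% to 100%.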

Compound 4, a percentage reported as inhibition, in the whole organism at one dose (the size of the read-out at that dose, not a potency): 43%
Compound 4: the middle estimate sits 47 percentage points above what was measured, and the stated range ends above it.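

Bromo in place of fluoro on an aromatic carbon gave a number 35 percentage points lower from compound 3 to compound 4 (beyond the scatter), so in this assay this change does not carry over from the core of compound 1 to the core of compound 3: the same change on two cores in this assay, a number 26 percentage points higher (beyond the scatter) from compound 1 to compound 2 and a number 35 percentage points lower (beyond the scatter) from compound 3 to compound 4, 61 percentage points apart, beyond the scatter of two such steps. Bromo in place of hydrogen on an aromatic carbon gave a number 53 percentage points lower from compound 2 to compound 4 (beyond the scatter), so that change also depends on the core it is made on: the same change on two cores in this assay, a number 8 percentage points higher (within the scatter) from compound 1 to compound 3 and a number 53 percentage points lower (beyond the scatter) from compound 2 to compound 4, 61 percentage points apart, beyond the scatter of two such steps. Both comparisons rest on the same four compounds, so they record one dependence seen from two sides, at a single dose, and they do not show what lies behind it or whether it would appear on any other core.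

Open, on these data alone, is whether the fall at compound 4 is particular to bromo, which a chloro, methyl or methoxy group on the same aromatic carbon, para to a bromo group, would help to settle. Also open, as far as these compounds go, is whether a larger change at that carbon, such as an amine or a carboxylic acid, would follow compound 3 or compound 4 in this assay.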